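The source may report more compounds than this note shows. Statements on the series, on what has been measured and on what is new or still open speak of the compounds shown alone.

In an assay on V79 cells for inhibition of cytochrome P450 11B2, mitochondrial (Homo sapiens), read by HTRF, with a stated time of 1 h (on this read-out higher numbers stand for weaker inhibition and lower numbers for stronger inhibition), the three measured compounds gave these numbers:
compound 1 `c1cncc(-c2nc3ccccc3n2C2CC2)c1` gives 49 nM;
compound 2 `Fc1ccc2nc(-c3cccnc3)n(C3CC3)c2c1` gives 4 nM;
compound 3 `COc1ccc2nc(-c3cccnc3)n(C3CC3)c2c1` gives 24 nM.

Compound 1 stands highest of the three numbers; the steps away from it are a 2.0-fold lower number from compound 1 to compound 3 (0.31 log units; beyond the scatter) and a 12-fold lower number from compound 1 to compound 2 (1.09 log units; beyond the scatter), both beyond the scatter.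

Compound 4 `Fc1cccc2c1nc(-c1cccnc1)n2C1CC1` differs from compound 1 by fluoro in place of hydrogen on an aromatic carbon, sitting on an aromatic carbon of a six-membered aromatic ring of carbon only, part of a fused system of two rings, ortho to a fused ring. The step that bears most directly on this change is a 12-fold lower number from compound 1 to compound 2 (1.09 log units; beyond the scatter), where the same group entered the same ring at another place and gave a large step. The step of a 2.0-fold lower number from compound 1 to compound 3 (0.31 log units; beyond the scatter) shows that a different group on that ring also lowered the number, though modestly. Because a 12-fold lower number from compound 1 to compound 2 (1.09 log units; beyond the scatter) was large, a lower number is expected for compound 4, but with the place of the fluoro changed a smaller step is estimated: a 4.1-fold lower number from compound 1 to compound 4 (0.61 log units; beyond the scatter). Compound 4 is therefore expected to give 12 nM, within a range from 4 nM to 40 nM.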

Compound 4, half-maximal inhibitory concentration: 219 nM
Beside the measured number, compound 4's estimate is 18-fold (1.26 log units) below it; the measured number lies above the stated range.
By their numbers in this assay, from the lowest: compound 2; then compound 3; then compound 1; then compound 4.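

In this assay, fluoro in place of hydrogen at this place, on an aromatic carbon ortho to a fused ring, gives a 4.5-fold higher number from compound 1 to compound 4 (0.65 log units; beyond the scatter), the only step from compound 1 shown here that raises the number. The same exchange at another place on that ring gave a 12-fold lower number from compound 1 to compound 2 (1.09 log units; beyond the scatter), so among these compounds the direction of the step follows the place of the fluoro and not the group alone. No measurement given here accounts for this reversal.

From the compounds shown here alone, what remains open is whether the higher number belongs to fluoro specifically or would appear with any group at this place, as a chloro, a methyl or an amine there could show. The compounds shown also leave open how fluoro behaves on the remaining carbons of that ring.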